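The source may report more compounds than this note shows. Statements on the series, on what has been measured and on what is new or still open speak of the compounds shown alone.

Three compounds share one core and differ only in the group on the oxygen on a saturated carbon. Compound 1 `CC(=O)OCCO[C@H](CC=C(C)C)C1=CC(=O)c2c(O)ccc(O)c2C1=O` carries a 2-acetoxyethyl there, and in a functional assay on HeLa cells (Homo sapiens) for cytotoxicity, read by MTT assay (a lower number here means a stronger inhibitor, a higher number a weaker inhibitor), compound 1 gives 41500 nM. Compound 2 `CC(C)=CC[C@@H](OC(=O)C1CCOC1)C1=CC(=O)c2c(O)ccc(O)c2C1=O` carries an (oxolan-3-yl)carbonyl, and in this assay compound 2 gives 73500 nM. Compound 3 `CCCC(O)CC(=O)O[C@H](CC=C(C)C)C1=CC(=O)c2c(O)ccc(O)c2C1=O` carries a (2-hydroxypentyl)carbonyl, and in this assay compound 3 gives 59300 nM. Compound 2 gives the largest of the three numbers, yet the step of a 1.8-fold higher number from compound 1 to compound 2 (0.25 log units; within the scatter) and the step of a 1.2-fold lower number from compound 2 to compound 3 (0.09 log units; within the scatter) both stay within the scatter, as does a 1.4-fold higher number from compound 1 to compound 3 (0.16 log units; within the scatter), so none of the three can be told apart on these numbers.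

Compound 4 `CCC(O)(CC)CC(=O)O[C@H](CC=C(C)C)C1=CC(=O)c2c(O)ccc(O)c2C1=O` has not been measured. It is compound 2 with 2-ethyl-2-hydroxybutyl in place of oxolan-3-yl on a carbonyl carbon. Going by the values given here, the one measured step that bears on this exchange is a 1.2-fold lower number from compound 2 to compound 3 (0.09 log units; within the scatter), where an open chain bearing a hydroxyl likewise replaced the oxolan-3-yl on the carbonyl carbon, and that step stayed within the scatter. The exchange is therefore expected to yield the step of a 1.2-fold lower number from compound 2 to compound 4 (0.07 log units; within the scatter), nothing beyond the scatter in either direction. For compound 4 the estimate in this assay is 62000 nM, with a range from 30000 nM to 125000 nM.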

Compound 4, half-maximal inhibitory concentration: 52000 nM
For compound 4 the middle estimate is 1.2-fold (0.08 log units) above the measured one, and the stated range covers the measured number.
By their numbers in this assay, from the lowest: compounds 1, 4, 3 and 2 (each within the scatter of the next).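

In this assay, replacing the oxolan-3-yl ring on the carbonyl carbon with the open 2-ethyl-2-hydroxybutyl chain, which also brings in a hydrogen-bond donor, gives a 1.4-fold lower number from compound 2 to compound 4 (0.15 log units; within the scatter), while swapping one hydroxyl-bearing open chain for the other gives a 1.1-fold lower number from compound 3 to compound 4 (0.06 log units; within the scatter). Compared with the 2-acetoxyethyl group on the oxygen on a saturated carbon, the (2-ethyl-2-hydroxybutyl)carbonyl group gives a 1.3-fold higher number from compound 1 to compound 4 (0.10 log units; within the scatter), so this fourth group also fails to separate itself from the other three, and the added ethyl branching of the new chain produces no readable change at this position. Nothing measured here offers an explanation for this flat result.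

From the compounds shown here alone, whether an amine or a carboxylic acid on this carbonyl carbon, or a much longer chain, would give a step beyond the scatter remains open. Going by these compounds, it is also open how a plain butyl chain without the hydroxyl would compare with the hydroxyl-bearing chains of compound 3 and compound 4.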